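The source may hold more compounds than are shown below. What is called first, only, known or untested is meant among the compounds shown, and "the series" means these compounds.

Measured compounds in an assay for inhibition of sodium- and chloride-dependent glycine transporter 1 (Homo sapiens); on this read-out higher numbers stand for an effect only at larger amounts of compound and lower numbers for an effect already at smaller amounts:
- Compound 1, `O=C(CNC(=O)c1ccc(F)cc1)NC(c1ccccc1)c1ccc(Cl)cc1`, gives 88 nM; 88 nM (2 entries).
- Compound 2, `O=C(CNC(=O)c1ccc(F)cc1)NC(c1ccccc1)c1cccc(Cl)c1`, gives 33 nM.
- Compound 3, `COc1ccc(C(NC(=O)CNC(=O)c2ccc(F)cc2)c2ccccc2)cc1`, gives 1100 nM.

All three share the same core and differ only in the group on one of the two aromatic rings attached to the carbon that carries the amide nitrogen. Compound 3 stands highest among these numbers; its nearest neighbour is compound 2, and the two values of compound 1 sit between them. Among the measured compounds shown here, the only single-point step into compound 3 is a 33-fold higher number from compound 2 to compound 3 (1.52 log units; beyond the scatter), a large move toward weaker binding when 4-methoxyphenyl replaced 3-chlorophenyl.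

Compound 4, `COc1ccc(C(NC(=O)CNC(=O)c2ccc(F)cc2)c2ccc(OC)cc2)cc1`, carries the change (methoxy in place of hydrogen on an aromatic carbon), so that both rings on that carbon now bear a methoxy group. For the measured compounds named here, no measured step adds a methoxy to a bare phenyl, so the expectation rests on the one step that introduced this group, which was large and in the weakening direction. A further methoxy on the second ring is therefore expected to shift this assay by a 2.3-fold higher number from compound 3 to compound 4 (0.36 log units; beyond the scatter), in the same direction or at most not beyond the scatter. Compound 4 is estimated at 2500 nM, within 800 nM to 8000 nM.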

Compound 4, half-maximal effective concentration: 6630 nM
Beside the measured number, compound 4's estimate is 2.7-fold (0.42 log units) below it; measured number inside the range.
By their numbers in this assay, from the lowest: compound 2; then compound 3; then compound 4.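

In this assay, changing phenyl to 4-methoxyphenyl on the second ring gives a 6.0-fold higher number from compound 3 to compound 4 (0.78 log units; beyond the scatter), so a methoxy group placed on a bare phenyl ring, para to a large group, weakens the effect even with nothing else leaving the molecule. The earlier step, a 33-fold higher number from compound 2 to compound 3 (1.52 log units; beyond the scatter), could not show this, since it removed a chlorine and brought in a methoxy at a different ring position in a single move, whereas this step is a clean addition and is modest rather than large. Both steps run in the same direction, but no measurement available here explains why the number rises when methoxy enters.

The compounds shown leave open whether this rise is particular to methoxy, since a hydroxy group, an amine or a fluorine at the same place on this ring could move the number differently. They also leave open what a methoxy on the second ring does when the first ring keeps its chlorine, as in a relative of compound 2, rather than the methoxy of compound 3.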